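A few compounds are considered here, and "the series" means these few. Any claim that something is new, unique, unknown or untested is made for them only; others in the source may bear on it.

Of the compounds shown here, two in a shared core have been measured in a functional assay on cells (Cancer cell lines, Homo sapiens) for cytotoxicity, read by sulforhodamine B assay, with a stated time of 48 h; on this read-out higher numbers stand for weaker inhibition of growth and lower numbers for stronger inhibition of growth. Compound 1, `COc1ccc(C2=NN(C3=NC(=O)/C(=C4\C(=O)Nc5ccccc54)S3)C(c3ccc(OC)cc3)C2)cc1`, gives 88100 nM in this assay. Compound 2, `O=C1N=C(N2N=C(c3ccccc3)CC2c2ccc(Cl)cc2)S/C1=C1/C(=O)Nc2ccccc21`, gives 230 nM in this assay, the lower of the two numbers and far apart from that of compound 1. Compound 1 and compound 2 differ in more than one place. Among the compounds with values here, the two numbers show only that the pair sits far apart, not which change matters.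

Compound 3, `COc1ccc(C2=NN(C3=NC(=O)/C(=C4\C(=O)Nc5ccccc54)S3)C(c3ccc(Cl)cc3)C2)cc1`, is not yet measured in this assay. It differs from compound 2 in one place: methoxy in place of hydrogen on an aromatic carbon. Within the data shown here, no single-change step of this kind is available among the measured compounds, so the expected size of the step rests on the gap between compound 1 and compound 2 alone. A moderate weakening is expected, with the step from compound 2 to compound 3 estimated as an 8.7-fold higher number from compound 2 to compound 3 (0.94 log units; beyond the scatter). The value of compound 3 is expected near 2000 nM, within a range from 300 nM to 15000 nM.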

Compound 3, concentration for 50% growth inhibition: 92400 nM
For compound 3 the middle estimate is 46-fold (1.66 log units) below the measured one; the measured number lies above the stated range.
By their numbers in this assay, from the lowest: compound 2; then compounds 1 and 3 (each within the scatter of the next).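

In this assay, replacing phenyl with 4-methoxyphenyl gives a 400-fold higher number from compound 2 to compound 3 (2.60 log units; beyond the scatter), so one added methoxy on this ring, para to a large group, is enough to take the series from strong to weak inhibition of growth. With that methoxy in place, the swap of chloro for methoxy at the other changed place gives a 1.0-fold higher number from compound 1 to compound 3 (0.02 log units; within the scatter), which leaves the two numbers indistinguishable. Nothing available explains why this methoxy has so large an effect.

From the compounds shown here alone, it remains open whether a fluoro, a hydroxyl or an amine at this same position would weaken growth inhibition as much as methoxy does, or whether the effect is specific to methoxy. Also open, going by these compounds, is whether the choice between chloro and methoxy at the other place would matter when this ring is plain phenyl.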